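The source may report more compounds than this note shows. Statements on the series, on what has been measured and on what is new or still open speak of the compounds shown alone.

- Compound 1 `CC(=O)N[C@@H]1CCC[C@H](C(=O)Nc2cc(-c3cnc4n3CCCC4)c(Cl)cn2)C1`: 600000 nM
- Compound 2 `CC(=O)N[C@@H]1CCC[C@H](C(=O)Nc2cc(-c3cnn4c3NCCC4)c(Cl)cn2)C1`: 860000 nM

In a physicochemical assay for solubility, in phosphate buffer, at pH 7.4 (a higher number here means a more soluble compound, a lower number a less soluble compound), compound 2 gives 860000 nM, within the scatter of compound 1. Compound 3 `CC(=O)N[C@@H]1CCC[C@H](C(=O)Nc2cc(-c3cnn4c3CC(C)(C)C4)c(Cl)cn2)C1` is not yet measured. Its change from compound 2 is a group of 10 heavy atoms (8 carbon, 2 nitrogen; one five-membered non-aromatic ring with 1 hetero atom, one five-membered aromatic ring with 2 hetero atoms) in place of a group of 9 heavy atoms (6 carbon, 3 nitrogen; one five-membered aromatic ring with 2 hetero atoms, one six-membered non-aromatic ring with 2 hetero atoms), on an aromatic carbon. Among the compounds with values here, only one measured step bears on this, a 1.4-fold higher number from compound 1 to compound 2 (0.16 log units; within the scatter), which also exchanged the group on an aromatic carbon and stayed within the scatter. In this assay, no change beyond the scatter is therefore expected, and the expected step is a 1.6-fold lower number from compound 2 to compound 3 (0.19 log units; within the scatter). The estimate for compound 3 is 550000 nM, with an expected range of 200000 nM to 1000000 nM.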

Compound 3, solubility: 150000 nM
Beside the measured number, compound 3's estimate is 3.7-fold (0.56 log units) above it; measured number outside the range, below it.
By their numbers in this assay, from the lowest: compound 3; then compounds 1 and 2 (each within the scatter of the next).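

In this assay, the group on this aromatic carbon proved able to move the number beyond the scatter: the result is a 5.7-fold lower number from compound 2 to compound 3 (0.76 log units; beyond the scatter), and likewise a 4.0-fold lower number from compound 1 to compound 3 (0.60 log units; beyond the scatter), whereas the earlier exchange of bicyclic groups did not. The group in compound 3 is the only one shown with a five-membered non-aromatic ring, and no measurement here explains the difference.

The compounds shown do not separate the effect of ring size from that of the added carbon atoms. On these data alone, whether an amine or a carboxylic acid on that five-membered non-aromatic ring would change the number also remains open.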